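This account rests on a few compounds, and the source may have more. Where it says the series, first, only, none or still open, it means among the compounds named here.

Series notes. Compound 1 `O=C(Nc1cccc(-n2cc(-c3ccncc3)c(-c3ccc(Cl)c(O)c3)n2)c1)Nc1cccc(C(F)(F)F)c1` carries a 4-chloro-3-hydroxyphenyl on the shared core with a 3-(trifluoromethyl)phenyl on the amide-type nitrogen; in a functional assay on HCT-116 cells (Homo sapiens) for inhibition, read by sulforhodamine B assay, with a stated time of 48 h (on this read-out lower numbers stand for stronger inhibition of growth and higher numbers for weaker inhibition of growth), compound 1 gives 8260 nM. Compound 2 `O=C(Nc1cccc(-n2cc(-c3ccncc3)c(-c3ccc(Cl)c(O)c3)n2)c1)Nc1ccc(Cl)c(Cl)c1` keeps that core with a 3,4-dichlorophenyl on the amide-type nitrogen, and in this assay compound 2 gives 5730 nM; the step of a 1.4-fold lower number from compound 1 to compound 2 (0.16 log units; within the scatter) stays within the scatter. Compound 3 `COc1cc(-c2nn(-c3cccc(NC(=O)Nc4ccc(Cl)c(C(F)(F)F)c4)c3)cc2-c2ccncc2)ccc1Cl` pairs a further aryl on the amide-type nitrogen with a 4-chloro-3-methoxyphenyl; in this assay compound 3 gives 4560 nM, the lowest of the three numbers, though its gaps to compound 2 and to compound 1 both lie within the scatter. Compound 4 `O=C(Nc1cccc(-n2cc(-c3ccncc3)c(-c3ccc(Cl)c(O)c3)n2)c1)Nc1ccc(Cl)c(C(F)(F)F)c1` differs from compound 3 by hydrogen in place of methyl on an oxygen on an aromatic ring. Among the measured compounds shown here, no measured pair isolates this change: the one measured step, from compound 1 to compound 2, alters the aryl on the amide-type nitrogen, not the oxygen. The values of compound 1, compound 2 and compound 3 all sit within the scatter of one another. For compound 4 the expectation is therefore no step beyond the scatter, a 1.1-fold higher number from compound 3 to compound 4 (0.04 log units; within the scatter), an estimate of 5000 nM with a range from 2000 nM to 12000 nM.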

Compound 4, concentration for total growth inhibition: 3940 nM
Compound 4: the middle estimate sits 1.3-fold (0.10 log units) above what was measured; the measured number falls inside the stated range.
By their numbers in this assay, from the lowest: compounds 4, 3, 2 and 1 (each within the scatter of the next, the first and the last beyond it).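

Methoxy to hydroxy on the aromatic ring now has its first measured pair: in this assay the change gives a 1.2-fold lower number from compound 3 to compound 4 (0.06 log units; within the scatter) with the aryl on the amide-type nitrogen held constant, so this read-out does not separate the two groups. On that aryl, trifluoromethyl in place of chloro on an aromatic carbon gives a 1.5-fold lower number from compound 2 to compound 4 (0.16 log units; within the scatter) and is also unresolved, whereas chloro in place of hydrogen on an aromatic carbon gives a 2.1-fold lower number from compound 1 to compound 4 (0.32 log units; beyond the scatter) as the only step shown beyond the scatter, and a modest one. No measurement here bears on the cause of any of these steps.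

The compounds shown leave open whether an amine or a longer ether chain such as ethoxy at this position would move the number beyond the scatter. Going by these compounds, whether methoxy and hydroxy also match with other aryl groups on the amide-type nitrogen remains open too.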